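A few compounds are considered here, and "the series" means these few. Any claim that something is new, unique, unknown or untested is made for them only; others in the source may bear on it.

Compound 3 `Cc1ccc(S(=O)(=O)N[C@@H](CC(=O)NC(C)(C)C)C(=O)NCCNC(=O)c2cccc(C(F)(F)F)c2)cc1` stands in an ADME assay on HepG2 cells (Homo sapiens) for cytotoxicity (on this read-out higher numbers stand for an effect only at larger amounts of compound and lower numbers for an effect already at smaller amounts), at the assay limit, reported as > 11000 nM rather than as a number. Compound 1 `Cc1ccc(S(=O)(=O)N[C@@H](CC(=O)NC(C)(C)C)C(=O)NCCNC(=O)c2cccc(O)c2)cc1` likewise sits at the limit, giving > 11000 nM. Compound 2 `Cc1ccc(S(=O)(=O)N[C@@H](CC(=O)NC(C)(C)C)C(=O)NCCNC(=O)c2ccc(F)cc2)cc1` returns > 11000 nM, again only a limit. Hence a step that the two limits leave unreadable from compound 1 to compound 2, a step that the two limits leave unreadable from compound 1 to compound 3 and a step that the two limits leave unreadable from compound 2 to compound 3 cannot be sized, and the limit of > 11000 nM in this assay, at which 3 of the 3 values shown sit, is all the series shows so far. The change to compound 4 `Cc1ccc(S(=O)(=O)N[C@@H](CC(=O)NC(C)(C)C)C(=O)NCCNC(=O)c2ccc(Cl)cc2)cc1` is 4-chlorophenyl in place of 3-(trifluoromethyl)phenyl on a carbonyl carbon. The steps that exchange the aryl group on the carbonyl carbon, starting from compound 1 and from compound 2, bear on it, but none has a readable size. No step beyond the scatter is therefore expected in this assay; the expected step is a step that the limit leaves unreadable from compound 3 to compound 4. For compound 4 the estimate is 15000 nM, with a range from 8000 nM to 40000 nM, most likely reported again only as a limit.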

Compound 4, half-maximal effective concentration: > 11000 nM
Compound 4 ended at the assay's limit; the forecaster's own chance of this, stated with the estimate: 85%; the middle value is on the limit's open side.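

In this assay compound 4 gives > 11000 nM, again a limit and not a number, so no step from compound 1, compound 2 or compound 3 to compound 4 can be read: the limit of > 11000 nM in this assay, at which 4 of the 4 values shown sit.

The compounds shown leave open whether any aryl group on the carbonyl carbon changes this read-out at all.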